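Swapping a Methoxy for an Amide: Expected Cell Tolerance

A few compounds are considered here, and "the series" means these few. Any claim that something is new, unique, unknown or untested is made for them only; others in the source may bear on it.

Compound 1, `COc1ccc(-c2nc3cc(C(F)(F)F)ccc3[nH]2)c(OC)c1`: > 100000 nM
Compound 2, `O=[N+]([O-])c1ccc(-c2nc3cc(C(F)(F)F)ccc3[nH]2)cc1`: 18000 nM
Compound 3, `COc1ccc(-c2nc3cc(C(F)(F)F)ccc3[nH]2)cc1`: > 100000 nM

Of the compounds shown here, three sharing one core have been tested in an ADME assay on BHK cells (Mesocricetus auratus) for cytotoxicity, read by MTT assay, with a stated time of 96 h; a lower number here means that less compound is tolerated, a higher number that more compound is tolerated. For compound 1 the result is a limit of the assay, > 100000 nM. For compound 3 the result is likewise a limit, > 100000 nM. Compound 2, carrying a nitro group, gives a true number, 18000 nM. The step that the two limits leave unreadable from compound 1 to compound 3 cannot be sized, because both ends sit at the limit of > 100000 nM in this assay, at which 2 of the 3 values shown sit. The step of an at least 5.5-fold higher number from compound 2 to compound 3 (0.74 log units; beyond the scatter) is readable only as a lower bound, since compound 3 itself is at a limit.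

Compound 3 thus stands where most of the shown values stand, at the limit of > 100000 nM in this assay, at which 2 of the 3 values shown sit, among the best tolerated compounds shown. Compound 4, `O=C(CN1CCCC1)Nc1ccc(-c2nc3cc(C(F)(F)F)ccc3[nH]2)cc1`, differs from compound 3 by (((pyrrolidin-1-yl)methyl)carbonyl)amino in place of methoxy on an aromatic carbon. Going by the values given here, no measured step covers an amide of this kind; the one readable step only shows that a methoxy is tolerated better than a nitro. Among the compounds with values here, with no closer precedent, compound 4 is expected to be tolerated somewhat less well than compound 3, with an estimated step of an at least 2.0-fold lower number from compound 3 to compound 4 (0.30 log units; that floor lies within the scatter). The estimate for compound 4 is 50000 nM, within a range from 12000 nM to 100000 nM.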

Compound 4, half-maximal cytotoxic concentration: 29000 nM
For compound 4 the middle estimate is 1.7-fold (0.24 log units) above the measured one, within the range that was stated.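

This result shows that the position on the six-membered aromatic ring, para to a large group, responds to a second kind of group, not only to nitro: in this assay, (((pyrrolidin-1-yl)methyl)carbonyl)amino in place of methoxy gives an at least 3.4-fold lower number from compound 3 to compound 4 (0.53 log units; beyond the scatter). That size is only a floor, because compound 3 sits at a limit of the assay: the limit of > 100000 nM in this assay, at which 2 of the 4 values shown sit. The new group is far larger than nitro and brings a five-membered non-aromatic ring and an amide hydrogen, yet the change of nitro to this group gives a 1.6-fold higher number from compound 2 to compound 4 (0.21 log units; within the scatter), so these two compounds cannot be told apart here.

The compounds shown do not separate the contributions of the amide and the pyrrolidine ring, and they give no reason for the lower number in compound 4. A plain amine or a carboxylic acid at this position, or a longer chain between the carbonyl and the ring, would help show which part of the new group matters for how well the cells tolerate the compound.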